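A few compounds are considered here, and "the series" means these few. Any claim that something is new, unique, unknown or untested is made for them only; others in the source may bear on it.

Three compounds have been measured in a functional assay on HL-60 cells (Homo sapiens) for inhibition, read by resazurin assay, with a stated time of 72 h; a higher number here means a weaker inhibitor, a lower number a stronger inhibitor:

Compound 1 `COc1cc(N2C(=O)CC2c2ccc(SC)cc2)cc(OC)c1OC`: 69 nM
Compound 2 `CCSc1ccc(C2C(Oc3ccccc3)C(=O)N2c2cc(OC)c(OC)c(OC)c2)cc1`: 508 nM
Compound 3 `COc1ccc(C2C(Oc3ccccc3)C(=O)N2c2cc(OC)c(OC)c(OC)c2)cc1`: 19 nM

Compound 3, at 19 nM, has the lowest number of the three, and both other values lie beyond the scatter from it. Compound 4 `COc1cc(N2C(=O)C(Oc3ccccc3)C2c2ccc(SC)cc2)cc(OC)c1OC` is compound 3 with methylsulfanyl in place of methoxy on an aromatic carbon, para to a large group (methylsulfanyl in place of methoxy on an aromatic carbon).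

For the measured compounds named here, one measured step bears directly on this change: a 27-fold lower number from compound 2 to compound 3 (1.43 log units; beyond the scatter), a large step that exchanges ethylsulfanyl for methoxy. Run in reverse, it suggests that compound 4 should show a higher number in this assay than compound 3. As that step involved ethylsulfanyl rather than methylsulfanyl, it gives the direction and only a rough upper guide to size. Compound 1 also carries methylsulfanyl, on a different core, and gives 69 nM. A moderate rise, beyond the scatter but smaller than the measured step, is therefore expected. The expected change is a 5.3-fold higher number from compound 3 to compound 4 (0.72 log units; beyond the scatter). For compound 4 the estimated value is 100 nM, with an expected range of 35 nM to 300 nM.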

Compound 4, half-maximal inhibitory concentration: 388 nM
The estimate for compound 4 lay 3.9-fold (0.59 log units) below the measured number; the measured number lies above the stated range.
By their numbers in this assay, from the lowest: compound 3; then compound 1; then compounds 4 and 2 (each within the scatter of the next).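

In this assay, for the compounds shown here, methylsulfanyl in place of methoxy, para to a large group, proves a large loss on the shared core (a 20-fold higher number from compound 3 to compound 4 (1.31 log units; beyond the scatter)), well beyond the moderate rise that the earlier compounds suggested. Shortening the sulfur-bound chain makes no difference beyond the scatter (a 1.3-fold lower number from compound 2 to compound 4 (0.12 log units; within the scatter)), so methylsulfanyl and ethylsulfanyl cannot be told apart here, and the sharp contrast lies between methoxy and these two sulfur groups. Phenoxy on the saturated ring carbon also does not help when methylsulfanyl is present (a 5.6-fold higher number from compound 1 to compound 4 (0.75 log units; beyond the scatter)), so the low number of compound 3 cannot be credited to phenoxy alone.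

On these data alone, whether phenoxy has the same effect alongside methoxy stays open, as does how ethoxy, hydroxy or chlorine would behave at this place. Nothing available here accounts for the gap between methoxy and the sulfur groups.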